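Three Chlorophenyl Analogues of a Terpene Cytotoxicity Series

The source may report more compounds than this note shows. Statements on the series, on what has been measured and on what is new or still open speak of the compounds shown alone.

Compound 1 `CC1=CC[C@@H]([C@@](C)(O)CCCC(C)(C)NC(=S)NN)CC1`: > 100000 nM
Compound 2 `CC1=CC[C@@H]([C@@](C)(O)CCCC(C)(C)NC(=S)N/N=C\c2ccccc2Cl)CC1`: > 100000 nM
Compound 3 `CC1=CC[C@@H]([C@@](C)(O)CCCC(C)(C)NC(=S)N/N=C\c2cccc(Cl)c2)CC1`: 45900 nM

All three were tested in a functional assay on MCF7 cells (Homo sapiens) for cytotoxicity, read by sulforhodamine B assay; on this read-out lower numbers stand for higher toxicity in this test and higher numbers for lower toxicity in this test. For compound 1 the value > 100000 nM is a limit of the assay, not a number. For compound 2 the value > 100000 nM is likewise only a limit. Compound 3 gives 45900 nM. Compound 1 thus stands at the upper edge of what this assay reports, as shown by the limit of > 100000 nM in this assay, at which 2 of the 3 values shown sit.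

Compound 4 `CC1=CC[C@@H]([C@@](C)(O)CCCC(C)(C)NC(=S)N/N=C\c2ccc(Cl)cc2)CC1` differs from compound 1 by a group of 9 heavy atoms (7 carbon, 1 nitrogen, 1 chlorine; one six-membered aromatic ring of carbon only) in place of one nitrogen atom, on an amide-type nitrogen. Two measured steps make the same kind of change: a step that the two limits leave unreadable from compound 1 to compound 2, and an at least 2.1-fold lower number from compound 1 to compound 3 (0.33 log units; beyond the scatter). The third step, an at least 2.1-fold lower number from compound 2 to compound 3 (0.33 log units; beyond the scatter), separates the two chlorophenyl placements. Accordingly the step from compound 1 to compound 4 is expected to be modest at most, downward if readable: an at least 1.6-fold lower number from compound 1 to compound 4 (0.22 log units; that floor lies within the scatter). Compound 4 is expected at 60000 nM, between 20000 nM and 200000 nM.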

Compound 4, concentration lethal to 50% of the cells: 44300 nM
The estimate for compound 4 lay 1.4-fold (0.13 log units) above the measured number; the range from low to high includes it.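

Against the 3-chlorophenyl group, the 4-chlorophenyl group gives a 1.0-fold lower number from compound 3 to compound 4 (0.02 log units; within the scatter) and so the two placements read alike. The change on the amide-type nitrogen shows an at least 2.2-fold lower number from compound 1 to compound 4 (0.35 log units; beyond the scatter) for a second placement, and replacing the 2-chlorophenyl group gives an at least 2.2-fold lower number from compound 2 to compound 4 (0.35 log units; beyond the scatter) as well. Both sizes are floors only, since compound 1 and compound 2 carry limits, not numbers: the limit of > 100000 nM in this assay, at which 2 of the 4 values shown sit. The compounds shown leave open how far those two gaps truly run. They also leave open whether a fluorine atom or a methoxy group in place of the chlorine would read alike.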